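Replacing dimethoxyphenyl with difluorophenyl: an expected gain

A few compounds are considered here, and "the series" means these few. Any claim that something is new, unique, unknown or untested is made for them only; others in the source may bear on it.

Measured compounds:
- compound 1 `COc1ccc(Nc2nc(Nc3cc(C)[nH]n3)cc(N3CCN(C)CC3)n2)cc1OC` gives 459 nM in a functional assay on MDA-MB-231 cells (Homo sapiens) for antiproliferative activity, read by CCK-8 assay, with a stated time of 48 h; a higher number here means a weaker inhibitor, a lower number a stronger inhibitor
- compound 2 `Cc1cc(Nc2cc(N3CCN(C)CC3)nc(Nc3ccc(Cl)c(Cl)c3)n2)n[nH]1` gives 84.9 nM in this assay

Of these two compounds, compound 1 has the higher number and is the weaker inhibitor. Compound 3 `Cc1cc(Nc2cc(N3CCN(C)CC3)nc(Nc3ccc(F)c(F)c3)n2)n[nH]1` has not yet been measured. Its difference from compound 1 is 3,4-difluorophenyl in place of 3,4-dimethoxyphenyl on a nitrogen on an aromatic ring with 3,4-difluorophenyl in place of 3,4-dimethoxyphenyl on a nitrogen on an aromatic ring. Among the measured compounds shown here, one measured step bears on this change: 3,4-dichlorophenyl replacing the same 3,4-dimethoxyphenyl gave a 5.4-fold lower number from compound 1 to compound 2 (0.73 log units; beyond the scatter) and that is a single example. A step in the same direction is therefore expected in this assay but its size is uncertain. An estimated 3.5-fold lower number from compound 1 to compound 3 (0.55 log units; beyond the scatter) is expected, somewhat smaller than the measured step. Compound 3 is expected at about 130 nM with an estimated range from 50 nM to 340 nM in this assay.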

Compound 3, half-maximal inhibitory concentration: 160 nM
The estimate for compound 3 lay 1.2-fold (0.09 log units) below the measured number, and the stated range covers the measured number.
By their numbers in this assay, from the lowest: compounds 2 and 3 (each within the scatter of the next); then compound 1.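

In this assay, a second halogen-bearing ring also gives a gain over the 3,4-dimethoxyphenyl group (a 2.9-fold lower number from compound 1 to compound 3 (0.46 log units; beyond the scatter)), so the earlier gain no longer rests on 3,4-dichlorophenyl alone. Exchanging one halogen pair for the other, 3,4-difluorophenyl in place of 3,4-dichlorophenyl, gives a step that these measurements cannot separate from repeat variation (a 1.9-fold higher number from compound 2 to compound 3 (0.28 log units; within the scatter)), so chlorine and fluorine cannot be told apart at this place. Nothing shown here explains why the 3,4-dimethoxyphenyl group carries the higher number.

From the compounds shown here alone, it remains open whether the gain needs halogens at all, or whether both ring substituents are required. A plain phenyl ring, a ring with a single fluorine, or one with a trifluoromethyl group or a nitrile on the same nitrogen would address those questions.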